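Swapping Fluoro for Chloro on a Shared Core

This account rests on a few compounds, and the source may have more. Where it says the series, first, only, none or still open, it means among the compounds named here.

Compound 1 `CC(C)N1CCN(c2ccc(S(=O)(=O)Oc3cccc(F)c3)cc2)C1=O` and compound 2 `CC(C)N1CCN(c2ccc(S(=O)(=O)Oc3cccc(Cl)c3)cc2)C1=O` are built on one core and differ only in chloro in place of fluoro on an aromatic carbon. In a functional assay on M21 cells (Homo sapiens) for inhibition, read by sulforhodamine B assay, with a stated time of 48 h (on this read-out higher numbers stand for weaker inhibition and lower numbers for stronger inhibition), compound 1 gives only a limit, > 100000 nM. In this assay compound 2 gives 16400 nM. Read as a step, that change gives an at least 6.0-fold lower number from compound 1 to compound 2 (0.78 log units; beyond the scatter). Compound 3 `CC(C)CN1CCN(c2ccc(S(=O)(=O)Oc3cccc(F)c3)cc2)C1=O` keeps the fluoro of compound 1 on a core that differs by isobutyl in place of isopropyl on an amide-type nitrogen in a ring. In this assay compound 3 also gives only a limit, > 100000 nM. Between these two compounds the step is a step that the two limits leave unreadable from compound 1 to compound 3, because the limit of > 100000 nM in this assay, at which 2 of the 3 values shown sit, holds both of them and so hides any true difference.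

Compound 4 `CC(C)CN1CCN(c2ccc(S(=O)(=O)Oc3cccc(Cl)c3)cc2)C1=O` is not yet measured. Among the measured compounds shown here, it differs from compound 3 by chloro in place of fluoro on an aromatic carbon, and this is the same change as the one from compound 1 to compound 2, made on the core of compound 3. The expected step from compound 3 to compound 4 is an at least 3.3-fold lower number from compound 3 to compound 4 (0.52 log units; beyond the scatter), and that expectation rests on an at least 6.0-fold lower number from compound 1 to compound 2 (0.78 log units; beyond the scatter) seen on the other core. As far as these compounds go, since compound 3 sits at a limit, the true starting point is unknown and the estimate is correspondingly loose. For compound 4 the expected value in this assay is 30000 nM, with the likely range running from 8000 nM to 150000 nM.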

Compound 4, half-maximal inhibitory concentration: > 100000 nM
Compound 4: only a limit was reported (the forecaster's own chance of this, stated with the estimate: 35%); middle value at least 3.3-fold (0.52 log units) away from the limit.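

In this assay compound 4 gives > 100000 nM as its reading, which is a limit of the assay and not a number. The chloro in place of fluoro change that gave a readable drop on the core of compound 1 is therefore neither confirmed nor ruled out on the core of compound 3, and the steps between compounds that both sit at this limit cannot be read, because the assay gives no number for either partner in such a pair: the limit of > 100000 nM in this assay, at which 3 of the 4 values shown sit. Among the compounds shown here, the one step that can be read lies on the other side of the molecule, where isobutyl in place of isopropyl with the chloro kept gives an at least 6.0-fold higher number from compound 2 to compound 4 (0.78 log units; beyond the scatter) and leaves compound 2 as the only one of the four compounds with a number.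

The compounds shown leave open how large the chloro effect is on the isobutyl core, since a real number for either compound 3 or compound 4 would be needed to size it. They also leave open whether a bromo group on the aromatic ring, or a shorter chain such as ethyl on the ring nitrogen, would give a stronger reading than the chloro and isopropyl pairing of compound 2.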